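The compounds below may be only part of what the source reports. "The series", "measured", "known", "first", "only" and "open" are said of these compounds alone.

Working notes on a small series built on one shared core. Among the measured compounds shown here, compound 1 `Cc1nc(SCC(=O)Nc2nc(-c3ccc(Cl)cc3)cs2)n(Nc2ccccc2)c1C` is the only member with a numeric result so far: in a functional assay on HT-29 cells (Homo sapiens) for antiproliferative activity, read by sulforhodamine B assay, with a stated time of 48 h (on this read-out lower numbers stand for higher toxicity in this test and higher numbers for lower toxicity in this test), compound 1 gives 49500 nM. Compound 2 `Cc1ccc(Nn2c(SCC(=O)Nc3nc(-c4ccccc4)cs3)nc(C)c2C)cc1` is reported only as a limit of the assay, the point at which one of the two values sits (the limit of > 100000 nM in this assay, at which 1 of the 2 values shown sits). In this assay compound 2 gives > 100000 nM. For the measured compounds named here, compound 2 differs from compound 1 in more than one place, so no single step connects them and the two values show only that neither is strongly active. The next member, compound 3 `COc1ccc(Nn2c(SCC(=O)Nc3nc(-c4ccc(Cl)cc4)cs3)nc(C)c2C)cc1`, differs from compound 1 in a single place: methoxy in place of hydrogen on an aromatic carbon. Going by the values given here, no measured step in the set covers such a change. The change is expected to move the result little, if at all, beyond the scatter, so a step of a 1.2-fold higher number from compound 1 to compound 3 (0.08 log units; within the scatter) is estimated. For compound 3 an expected value of 60000 nM is taken, with a range from 20000 nM to 150000 nM, resting on compound 1 and its 49500 nM.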

Compound 3, concentration lethal to 50% of the cells: > 100000 nM
Compound 3 was reported as a limit; the forecaster's own chance of this, stated with the estimate: 35%; middle value at least 1.6-fold (0.22 log units) from the limit.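

The series now has its first single-place step in this assay: methoxy in place of hydrogen, on the aromatic carbon para to a large group, gives an at least 2.0-fold higher number from compound 1 to compound 3 (0.30 log units; that floor lies within the scatter). That step is only a floor, set by a limit of the assay, and its true size cannot be read: the limit of > 100000 nM in this assay, at which 2 of the 3 values shown sit. Methoxy at this position therefore brings no gain in toxicity in this test, while a change beyond the scatter is neither shown nor ruled out.

Open, on these data alone, is whether an amine or a carboxylic acid at this same position would give a lower number than compound 1 in this assay. Also open, as far as these compounds go, is whether any change on this ring can give a step that lies clearly beyond the scatter.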